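Phenyl for Methyl on a Core Without a Measured Value

The source may hold more compounds than are shown below. What is called first, only, known or untested is meant among the compounds shown, and "the series" means these compounds.

Compound 1 `Cc1cc2nc(C)c(CN)c(-c3ccc(Cl)cc3Cl)n2n1` was tested in an assay on isolated protein for inhibition of Dipeptidyl peptidase 9 (Homo sapiens); on this read-out lower numbers stand for stronger inhibition and higher numbers for weaker inhibition. In this assay compound 1 gives > 30000 nM, which is a limit of the assay and not a number. For the measured compounds named here, compound 2 `CCC(=O)c1cnn2c(-c3ccc(Cl)cc3Cl)c(CN)c(C)nc12` is the only other measured compound. In this assay compound 2 gives > 30000 nM, again a limit. Compound 1 thus stands at the limit of > 30000 nM in this assay, at which 2 of the 2 values shown sit, and nothing separates it from compound 2. Compound 3 `Cc1nc2cc(-c3ccccc3)nn2c(-c2ccc(Cl)cc2Cl)c1CN` differs from compound 1 in one place: phenyl in place of methyl on an aromatic carbon. Going by the values given here, no measured pair shows what this change does on the shared core, so the size of the step from compound 1 to compound 3 is unknown; with both measured values sitting at a limit, no shift beyond the usual scatter is expected, though a move toward stronger inhibition cannot be excluded. Compound 3 is therefore expected to come in near 20000 nM, between 3000 nM and 100000 nM. The expected step is an at least 1.5-fold lower number from compound 1 to compound 3 (0.17 log units; that floor lies within the scatter).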

Compound 3, inhibition constant: > 20000 nM
Compound 3 was reported as a limit (the forecaster's own chance of this, stated with the estimate: 60%); the middle value sits exactly at the limit.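

In this assay, for the compounds shown here, compound 3 gives > 20000 nM, a limit of the assay, and since compound 1 also stands at a limit, no step between compound 1 and compound 3 can be read. The compounds shown leave open whether phenyl in place of methyl on an aromatic carbon changes inhibition at all.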